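This account rests on a few compounds, and the source may have more. Where it says the series, first, only, none or still open, it means among the compounds named here.

Measured compounds:
compound 1, `COc1ncc(-c2ccc3ncnc(Nc4ccc(OCCO)cc4)c3c2)cc1NS(=O)(=O)c1ccc(F)cc1F`, gives 1060 nM
compound 2, `COc1ncc(-c2ccc3ncnc(Nc4ccc(OCCCO)nc4)c3c2)cc1NS(=O)(=O)c1ccc(F)cc1F`, gives 3680 nM
compound 3, `COC(=O)Cn1cc(Nc2ncnc3ccc(-c4cnc(OC)c(NS(=O)(=O)c5ccc(F)cc5F)c4)cc23)cn1`, gives 1260 nM

All three values come from a functional assay on HCT-116 cells (Homo sapiens) for antiproliferative activity, read by sulforhodamine B assay, with a stated time of 72 h; a lower number here means a stronger inhibitor, a higher number a weaker inhibitor. Compound 3 holds the second highest of the three numbers; its nearest neighbour is reached by a 1.2-fold higher number from compound 1 to compound 3 (0.08 log units; within the scatter), its furthest by a 2.9-fold lower number from compound 2 to compound 3 (0.47 log units; beyond the scatter). Going by the values given here, the one step among the measured compounds that moves clearly upward is a 3.5-fold higher number from compound 1 to compound 2 (0.54 log units; beyond the scatter).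

Compound 4, `COc1ncc(-c2ccc3ncnc(Nc4cnn(CCCO)c4)c3c2)cc1NS(=O)(=O)c1ccc(F)cc1F`, has not yet been measured. It differs from compound 3 by 2-hydroxyethyl in place of methoxycarbonyl on a saturated chain carbon bound to an aromatic nitrogen. Among the compounds with values here, none of the measured steps tests this exchange on the same ring, so they bear on it only loosely. a 1.2-fold higher number from compound 1 to compound 3 (0.08 log units; within the scatter) shows that the methoxycarbonyl-bearing group of compound 3 sits within the scatter of a hydroxy-ended chain on another ring, and a 2.9-fold lower number from compound 2 to compound 3 (0.47 log units; beyond the scatter) shows a modest gain over a second hydroxy-ended chain. Hydroxy-ended chains therefore appear both on a compound close to compound 3 and on one modestly weaker. The step into compound 4 is expected to be small, a 1.2-fold higher number from compound 3 to compound 4 (0.08 log units; within the scatter), with no clear direction beyond the scatter. Compound 4 is expected to give 1500 nM in this assay, with a range from 600 nM to 4000 nM.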

Compound 4, half-maximal inhibitory concentration: 480 nM
Compound 4: the middle estimate sits 3.1-fold (0.49 log units) above what was measured; measured number below the stated range.
By their numbers in this assay, from the lowest: compound 4; then compounds 1 and 3 (each within the scatter of the next); then compound 2.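

In this assay, going by these compounds alone, the exchange of methoxycarbonyl for 2-hydroxyethyl on a saturated chain carbon bound to an aromatic nitrogen gives a 2.6-fold lower number from compound 3 to compound 4 (0.42 log units; beyond the scatter) as the one comparison on the same ring, a modest step showing that the end of this chain affects the number. The 1-(3-hydroxypropyl)-1H-pyrazol-4-yl group also compares well with the other two hydroxy-ended groups: replacing 4-(2-hydroxyethoxy)phenyl gives a 2.2-fold lower number from compound 1 to compound 4 (0.34 log units; beyond the scatter) and replacing 6-(3-hydroxypropoxy)pyridin-3-yl gives a 7.7-fold lower number from compound 2 to compound 4 (0.88 log units; beyond the scatter), which makes compound 4 the strongest of the four compounds in this set. Nothing shown gives a measured reason for any of these steps.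

The compounds shown leave open whether the free hydroxyl itself matters, since a methyl ether at the chain end would separate its contribution from that of the lost ester. They also leave open how a carboxylic acid or an amine at the same chain end, or a longer chain carrying the hydroxyl, would compare with compound 4 in this assay on this ring.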